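The compounds below may be only part of what the source reports. "The series", "measured", "known", "first", "only" and "open" are said of these compounds alone.

Compound 1 `O=C(CSc1nc(Nc2ccccc2)c2ccccc2n1)Nc1ccccc1Br` gives 10300 nM in a functional assay on NCI-H1975 cells (Homo sapiens) for inhibition, read by MTT assay, with a stated time of 72 h; a lower number here means a stronger inhibitor, a higher number a weaker inhibitor. Compound 2 `O=C(CSc1nc(Nc2ccccc2)c2ccccc2n1)Nc1ccc(Br)cc1` gives 10600 nM in this assay.

Compound 1 holds the lower of the two numbers, but the step of a 1.0-fold higher number from compound 1 to compound 2 (0.01 log units; within the scatter) lies within the scatter, so the two compounds cannot be told apart. Compound 3 `CCc1ccc(NC(=O)CSc2nc(Nc3ccccc3)c3ccccc3n2)cc1` differs from compound 1 in one place: 4-ethylphenyl in place of 2-bromophenyl on an amide-type nitrogen. For the measured compounds named here, only the step from compound 1 to compound 2 bears on this change; there 4-bromophenyl in place of 2-bromophenyl left the number unchanged. Going by the values given here, no measured compound carries 4-ethylphenyl, so the expected step in this assay is a 1.0-fold lower number from compound 1 to compound 3 (0.01 log units; within the scatter), nothing beyond the scatter. Compound 3 is estimated at 10000 nM, ranging from 4000 nM to 30000 nM.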

Compound 3, half-maximal inhibitory concentration: 9910 nM
Compound 3: the middle estimate sits 1.0-fold (0.00 log units) above what was measured, within the range that was stated.
By their numbers in this assay, from the lowest: compounds 3, 1 and 2 (each within the scatter of the next).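

In this assay, 4-ethylphenyl in place of 2-bromophenyl on the amide-type nitrogen gives a 1.0-fold lower number from compound 1 to compound 3 (0.02 log units; within the scatter) and ethyl in place of bromo on an aromatic carbon gives a 1.1-fold lower number from compound 2 to compound 3 (0.03 log units; within the scatter). Compounds 1, 2 and 3 therefore cannot be told apart, so this place accepts an aromatic ring carrying ethyl as well as one carrying bromo, with no gain or loss that can be read. No evidence at hand accounts for this.

As far as these compounds go, whether an amine, a carboxylic acid or a longer chain on this ring would give a number beyond the scatter remains open.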